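Dichloro substitution on two carboxylic acid cores

This account rests on a few compounds, and the source may have more. Where it says the series, first, only, none or still open, it means among the compounds named here.

Compound 1 `O=C(O)C1CCN(c2ccccc2Cl)C1` carries a chloro on its aryl ring and, in an assay on cells for inhibition of Palmitoleoyl-protein carboxylesterase NOTUM variant C330S (Homo sapiens), read by fluorescence, with a stated time of 40 min (on this read-out higher numbers stand for weaker inhibition and lower numbers for stronger inhibition), compound 1 gives 19000 nM. Compound 2 `Cc1cc(C(=O)O)c(C)n1-c1cccc(Cl)c1` gives 430 nM and compound 3 `Cc1cc(C(=O)O)c(C)n1-c1ccc(Cl)c(Cl)c1` gives 270 nM; the difference between the core of compound 1 and the core of compound 2 is not broken down here. The step from compound 2 to compound 3 is chloro in place of hydrogen on an aromatic carbon, and it made a 1.6-fold lower number from compound 2 to compound 3 (0.20 log units; within the scatter). Compound 4 `O=C(O)C1CCN(c2c(Cl)cccc2Cl)C1` is related to compound 1 by chloro in place of hydrogen on an aromatic carbon, the same kind of change, though here the entering chloro sits ortho to a group of 8 heavy atoms and meta to a chloro group, whereas in compound 3 it sits ortho to a chloro group and para to a large group. Because the earlier step was a 1.6-fold lower number from compound 2 to compound 3 (0.20 log units; within the scatter), only a small step is expected for compound 4, namely a 1.5-fold lower number from compound 1 to compound 4 (0.16 log units; within the scatter). Compound 4 is therefore estimated at 13000 nM, expected to fall between 5000 nM and 35000 nM.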

Compound 4, half-maximal inhibitory concentration: 26000 nM
For compound 4 the middle estimate is 2.0-fold (0.30 log units) below the measured one; the measured number falls inside the stated range.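

In this assay, chloro in place of hydrogen on an aromatic carbon gives a 1.4-fold higher number from compound 1 to compound 4 (0.14 log units; within the scatter). Set beside the earlier step, the change reads the same on the two cores: the same change on two cores in this assay, a 1.6-fold lower number (0.20 log units; within the scatter) from compound 2 to compound 3 and a 1.4-fold higher number (0.14 log units; within the scatter) from compound 1 to compound 4, 2.2-fold (0.34 log units) apart, within the scatter of two such steps. Neither step lies beyond the scatter, so the added chloro shows no measurable effect on either core, but two such small steps do not show that the change would carry over to further cores or to other places on the aromatic ring.

Still open, as far as these compounds go, is whether an amine or a methoxy group on the aromatic ring would give a step beyond the scatter on either core. Also open, from the compounds shown here alone, is whether such a step would carry from one core to the other.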